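A New Carbonyl Substituent and Its Expected Solubility

The compounds below may be only part of what the source reports. "The series", "measured", "known", "first", "only" and "open" are said of these compounds alone.

Measured compounds:
Compound 1 `O=C(c1ccc(C(F)(F)F)cc1)N1CCC(NS(=O)(=O)c2cc(S(=O)(=O)c3ccccc3)ccc2C(F)(F)F)CC1`: 6300 nM
Compound 2 `O=C(O)c1ccc(N2CCC(NS(=O)(=O)c3cc(S(=O)(=O)c4ccccc4)ccc3C(F)(F)F)CC2)cc1`: 25000 nM

For the measured compounds named here, in a physicochemical assay for solubility (a higher number here means a more soluble compound, a lower number a less soluble compound), compound 1 gives 6300 nM, which is the lowest of the two numbers so far. Going by the values given here, its only neighbour is compound 2, reached by a 4.0-fold higher number from compound 1 to compound 2 (0.60 log units; beyond the scatter).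

Compound 3 `CC(C)(C)OC(=O)N1CC[C@H](C(=O)N2CCC(NS(=O)(=O)c3cc(S(=O)(=O)c4ccccc4)ccc3C(F)(F)F)CC2)C1` has not been measured yet. Compared with compound 1, the change is 1-(tert-butoxycarbonyl)pyrrolidin-3-yl in place of 4-(trifluoromethyl)phenyl on a carbonyl carbon. This is the only part of the shared core that is altered.

Among the compounds with values here, the one measured step that bears on this position is the one from compound 1 to compound 2, where the same 4-(trifluoromethyl)phenyl group left, there together with its carbonyl, and the number went up by a 4.0-fold higher number from compound 1 to compound 2 (0.60 log units; beyond the scatter). Compound 3 keeps the carbonyl and brings in a different group, so that step is only a partial guide. The expectation for compound 3 in this assay is a rise of similar or slightly smaller size, a 1.9-fold higher number from compound 1 to compound 3 (0.28 log units; within the scatter). The estimated solubility for compound 3 is 12000 nM, with a likely range from 4000 nM to 35000 nM.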

Compound 3, solubility: 25000 nM
The estimate for compound 3 lay 2.1-fold (0.32 log units) below the measured number, within the range that was stated.
By their numbers in this assay, from the lowest: compound 1; then compounds 2 and 3 (each within the scatter of the next).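

In this assay, the group on the carbonyl carbon can be exchanged while the carbonyl itself stays, and putting 1-(tert-butoxycarbonyl)pyrrolidin-3-yl in place of 4-(trifluoromethyl)phenyl gives a 4.0-fold higher number from compound 1 to compound 3 (0.60 log units; beyond the scatter). A rise beyond the scatter at this position therefore does not depend on losing the carbonyl, something the earlier step could not show, since the carbonyl left there along with the 4-(trifluoromethyl)phenyl group. The change swaps a six-membered aromatic ring of carbon only for a five-membered non-aromatic ring with one hetero atom, brings in hydrogen-bond acceptors where the leaving group had none, and adds a defined stereocentre, but no measurement here ties the rise to any one of these differences.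

The entering group has two parts, the tert-butoxycarbonyl group and the pyrrolidine ring, and the compounds shown do not separate them. A free pyrrolidine amine on the same carbonyl carbon, the opposite stereocentre, or a plain alkyl chain in that place would each test a different part of this change.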